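The source may hold more compounds than are shown below. What is called first, only, known or untested is meant among the compounds shown, and "the series" means these compounds.

Measured in a functional assay on K562 cells (Homo sapiens) for antiproliferative activity, read by MTT assay, with a stated time of 48 h; on this read-out lower numbers stand for stronger inhibition and higher numbers for weaker inhibition:
- Compound 1 `Cn1cc(C2=C(c3nn(CCCn4cncn4)c4ncccc34)C(=O)NC2=O)c2ccccc21`: > 100000 nM, a limit of the assay
- Compound 2 `Cn1cc(C2=C(c3nn(CCn4ccnc4)c4ncccc34)C(=O)N(c3ccccc3)C2=O)c2ccccc21`: 26400 nM
- Compound 3 `Cn1cc(C2=C(c3n[nH]c4ncccc34)C(=O)NC2=O)c2ccccc21`: > 100000 nM, a limit of the assay

Compound 3 gives no number, only the limit > 100000 nM. It thus belongs to the limit of > 100000 nM in this assay, at which 2 of the 3 values shown sit. Compound 4 `Cn1cc(C2=C(c3nn(CCn4ccnc4)c4ncccc34)C(=O)NC2=O)c2ccccc21` is reached from compound 3 by one change, 2-(1H-imidazol-1-yl)ethyl in place of hydrogen on an aromatic nitrogen.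

Among the measured compounds shown here, the only measured step at this nitrogen is a step that the two limits leave unreadable from compound 1 to compound 3, so it gives no size to carry over. For the measured compounds named here, it shows only that compound 1, with 3-(1H-1,2,4-triazol-1-yl)propyl at that place, does not rise out of the limit either. Going by the values given here, the one number comes from compound 2, which carries the same 2-(1H-imidazol-1-yl)ethyl but also differs from compound 4 elsewhere, and compound 2 gives 26400 nM.

In this assay a large gain is therefore not expected, and a small move toward stronger inhibition is the most that is foreseen. The estimated change is an at least 1.1-fold lower number from compound 3 to compound 4 (0.04 log units; that floor lies within the scatter), and a further limit reading is quite likely. Compound 4 is expected at about 90000 nM, with an estimated range from 30000 nM to 200000 nM.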

Compound 4, half-maximal inhibitory concentration: > 100000 nM
Compound 4 was reported as a limit; the forecaster's own chance of this, stated with the estimate: 60%; middle value at least 1.1-fold (0.04 log units) from the limit.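

In this assay, 2-(1H-imidazol-1-yl)ethyl on the aromatic nitrogen does not by itself bring the shared core out of the limit of the assay, and compound 4 stays among the compounds reported only as a limit: the limit of > 100000 nM in this assay, at which 3 of the 4 values shown sit.

Among the compounds shown here, the one readable step is the new information: hydrogen in place of phenyl on the amide-type nitrogen in a ring gives an at least 3.7-fold higher number from compound 2 to compound 4 (0.57 log units; beyond the scatter). For the compounds shown here, in this pair, then, the only measured number goes with the phenyl on that nitrogen, and the 2-(1H-imidazol-1-yl)ethyl group without it gives no number; the steps that join compound 4 to compound 3 and to compound 1 cannot be read, with limits at both ends.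

The compounds shown leave open whether phenyl on the amide-type nitrogen gives a number in this assay with only hydrogen on the aromatic nitrogen, so the share of each group in the value remains unknown. As far as these compounds go, it also remains open how a benzyl group or a longer chain would read on the amide-type nitrogen, or how a chain ending in an amine would read on the aromatic nitrogen.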